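A few compounds are considered here, and "the series" means these few. Any claim that something is new, unique, unknown or untested is made for them only; others in the source may bear on it.

In a functional assay on Bel7402/5-FU cells (Homo sapiens) for antiproliferative activity, read by MTT assay, with a stated time of 72 h (a lower number here means a stronger inhibitor, a higher number a weaker inhibitor), compound 1 `C=C1C(=O)O[C@H]2[C@H]1CC/C(COC(=O)Cn1cc(F)c(=O)n(Cc3ccccc3)c1=O)=C\CC[C@@]1(C)O[C@@H]21` gives 4270 nM, compound 2 `C=C1C(=O)O[C@H]2[C@H]1CC/C(COC(=O)Cn1cc(F)c(=O)n(Cc3ccc(F)cc3)c1=O)=C\CC[C@@]1(C)O[C@@H]21` gives 1140 nM and compound 3 `C=C1C(=O)O[C@H]2[C@H]1CC/C(COC(=O)Cn1cc(F)c(=O)n(Cc3ccc([N+](=O)[O-])cc3)c1=O)=C\CC[C@@]1(C)O[C@@H]21` gives 4340 nM. Compound 3 therefore stands level with compound 1, as a 1.0-fold higher number from compound 1 to compound 3 (0.01 log units; within the scatter) shows, while a 3.8-fold higher number from compound 2 to compound 3 (0.58 log units; beyond the scatter) sets it apart from compound 2. Compound 4 `C=C1C(=O)O[C@H]2[C@H]1CC/C(COC(=O)Cn1cc(F)c(=O)n(Cc3cccc(F)c3)c1=O)=C\CC[C@@]1(C)O[C@@H]21` differs from compound 3 as follows: 3-fluorophenyl in place of 4-nitrophenyl on a saturated chain carbon bound to an aromatic nitrogen. In short, it has 3-fluorophenyl in place of 4-nitrophenyl on a saturated chain carbon bound to an aromatic nitrogen. Among the compounds with values here, two measured steps bear most directly on this change: a 3.7-fold lower number from compound 1 to compound 2 (0.57 log units; beyond the scatter), with fluoro in place of hydrogen on an aromatic carbon, and the nitro step already given, which left the number unchanged within the scatter. Within the data shown here, no measured compound carries the 3-fluorophenyl group itself, so only part of the fluoro step is expected to carry over. The expected change is a 2.1-fold lower number from compound 3 to compound 4 (0.32 log units; beyond the scatter), smaller than the measured fluoro step. In this assay, the estimated value for compound 4 is 2100 nM, with an expected range of 1000 nM to 4500 nM.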

Compound 4, half-maximal inhibitory concentration: 3700 nM
For compound 4 the middle estimate is 1.8-fold (0.25 log units) below the measured one; the range from low to high includes it.
By their numbers in this assay, from the lowest: compound 2; then compounds 4, 1 and 3 (each within the scatter of the next).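

The earlier compounds shown here showed that adding fluoro could lower the number, and this result shows that the gain depends on where the fluoro sits. The 3-fluorophenyl group gives no measurable gain over the unsubstituted phenyl group (in this assay, a 1.2-fold lower number from compound 1 to compound 4 (0.06 log units; within the scatter)), while exchanging the 4-fluorophenyl group for it loses the gain (a 3.2-fold higher number from compound 2 to compound 4 (0.51 log units; beyond the scatter)). Exchanging the 4-nitrophenyl group for it also changes little (a 1.2-fold lower number from compound 3 to compound 4 (0.07 log units; within the scatter)), so of the four groups on this saturated chain carbon only 4-fluorophenyl stands apart, and nothing available explains this dependence on the place of the fluoro.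

On these data alone, it remains open whether the lower number is particular to fluoro, which a 4-chlorophenyl or 4-methoxyphenyl group on the same carbon could show. As far as these compounds go, how a longer chain in place of the benzyl link would behave also remains open.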